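Removing the methoxymethyl group from compound 1

The source may report more compounds than this note shows. Statements on the series, on what has been measured and on what is new or still open speak of the compounds shown alone.

compound 1 (`C=C1C=CC(=O)[C@@H]2[C@H](Cc3ccc(OCOC)c(F)c3)CC[C@H]12`): 106 nM
compound 2 (`C=C1C=CC(=O)[C@@H]2[C@H](Cc3ccccc3)CC[C@H]12`): 678 nM
compound 3 (`C=C1C=CC(=O)[C@@H]2[C@H](Cc3cc(OC)c(OC)c(OC)c3)CC[C@H]12`): > 1000 nM (a limit, not a number)

These results come from a functional assay on NCI-H460 cells (Homo sapiens) for antiproliferative activity, with a stated time of 72 h (a lower number here means a stronger inhibitor, a higher number a weaker inhibitor), and put compound 1 lowest of the two true numbers, with compound 2 higher by more than the usual scatter. Compound 4 (`C=C1C=CC(=O)[C@@H]2[C@H](Cc3ccc(O)c(F)c3)CC[C@H]12`) has hydrogen in place of methoxymethyl on an oxygen on an aromatic ring, turning methoxymethoxy into hydroxy. Among the measured compounds shown here, no measured pair isolates this change. Compound 2 at 678 nM shows how far a number can sit from compound 1 within this small set, so a moderate move toward weaker inhibition is expected. The expected change is a 2.8-fold higher number from compound 1 to compound 4 (0.45 log units; beyond the scatter), though none beyond the scatter remains possible. For compound 4 the estimated value is 300 nM, with an expected range from 90 nM to 1000 nM.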

Compound 4, half-maximal inhibitory concentration: 229 nM
Compound 4: the middle estimate sits 1.3-fold (0.12 log units) above what was measured; measured number inside the range.
By their numbers in this assay, from the lowest: compound 1; then compound 4; then compound 2. At a limit, above all of these: compound 3.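

Among the compounds shown here, this is the first pair that isolates the group on this oxygen: in this assay, hydrogen in place of methoxymethyl, turning methoxymethoxy into hydroxy, gives a 2.2-fold higher number from compound 1 to compound 4 (0.33 log units; beyond the scatter). The step is modest but beyond the scatter, so activity in these cells does not depend on keeping methoxymethyl, although compound 1 retains the lower number. Nothing measured here accounts for the step.

On these data alone, whether an ethyl group or a longer chain on this oxygen would give a lower or higher number remains open. So does what the fluorine contributes on its own.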